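Swapping a hydroxymethyl for bromo on a shared core

The source may hold more compounds than are shown below. What is called first, only, known or untested is meant among the compounds shown, and "the series" means these compounds.

Compound 2 `COn1c(-c2ccccc2)c(CO)c2cc(C#N)c(C#N)cc21`: 4990 nM
Compound 1 `COn1c(-c2ccccc2)c(C=O)c2cc(C#N)c(C#N)cc21`: 522 nM

Going by the values given here, in an assay on isolated protein for inhibition of Amine oxidase [flavin-containing] A (Homo sapiens), read by fluorescence and spectrophotometry, with a stated time of 20 min (a lower number here means a stronger inhibitor, a higher number a weaker inhibitor), compound 2 gives 4990 nM, the highest of the two numbers known; compound 1 gives 522 nM. Among the compounds with values here, the only known step, a 9.6-fold higher number from compound 1 to compound 2 (0.98 log units; beyond the scatter), shows that a change at this carbon can move the number clearly. Compound 3 `COn1c(-c2ccccc2)c(Br)c2cc(C#N)c(C#N)cc21` carries a bromo in place of hydroxymethyl on an aromatic carbon. Within the data shown here, no known step tests that exchange, so the direction is uncertain; a drop is expected, a 3.3-fold lower number from compound 2 to compound 3 (0.52 log units; beyond the scatter), with compound 3 estimated at 1500 nM (range 300 nM to 8000 nM).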

Compound 3, half-maximal inhibitory concentration: > 100000 nM
Compound 3: no number, only a limit (the forecaster's own chance of this, stated with the estimate: 10%); middle value at least 66-fold (1.82 log units) from the limit.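

Compound 3 gives only a limit, not a number: the limit of > 100000 nM in this assay, at which 1 of the 3 values shown sits. Putting bromo on this aromatic carbon gives an at least 20-fold higher number from compound 2 to compound 3 (1.30 log units; beyond the scatter), and exchanging formyl for bromo gives an at least 190-fold higher number from compound 1 to compound 3 (2.28 log units; beyond the scatter). The earlier step, a 9.6-fold higher number from compound 1 to compound 2 (0.98 log units; beyond the scatter), showed that this position can shift the number, whereas these steps show that a single exchange here can carry it to the limit of the assay.

From the compounds shown here alone, how far compound 3 lies past its limit stays unknown, so the full size of both new steps is open. Also open, going by these compounds, is how an amine, a carboxylic acid or a longer chain on this carbon would compare with formyl.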